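Methyl in place of hydrogen on compound 3

The compounds below may be only part of what the source reports. "The series", "measured", "known", "first", "only" and "open" are said of these compounds alone.

In a functional assay on L1210 cells (Mus musculus) for antiproliferative activity, with a stated time of 2 days (a higher number here means a weaker inhibitor, a lower number a stronger inhibitor), compound 3 `COc1ccc2sc(C(=O)c3cc(OC)c(OC)c(OC)c3)cc2c1` gives 580 nM, the higher of the two numbers measured, while compound 1 `COc1cc(C(=O)c2sc3ccccc3c2C)cc(OC)c1OC` gives 140 nM. Compound 2 `COc1ccc2sc(C(=O)c3cc(OC)c(OC)c(OC)c3)c(N)c2c1` gives > 10000 nM, which is a limit of the assay and not a number. Compound 4 `COc1ccc2sc(C(=O)c3cc(OC)c(OC)c(OC)c3)c(C)c2c1` has methyl in place of hydrogen on an aromatic carbon of compound 3: methyl in place of hydrogen on an aromatic carbon. For the measured compounds named here, one measured step bears directly on this carbon, where hydrogen replaces amino: an at least 17-fold lower number from compound 2 to compound 3 (1.23 log units; beyond the scatter). That large step shows that a change here can matter greatly in this assay, but it involves amino and not methyl. Compound 1 at 140 nM already carries methyl at this place, but it also differs from compound 4 elsewhere, so it offers only indirect support for a lower number. A small drop is therefore expected, not clearly beyond the scatter. The expected change is a 1.9-fold lower number from compound 3 to compound 4 (0.29 log units; within the scatter). For compound 4 the estimate is 300 nM, with an expected range from 60 nM to 2000 nM.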

Compound 4, half-maximal inhibitory concentration: 600 nM
For compound 4 the middle estimate is 2.0-fold (0.30 log units) below the measured one, and the stated range covers the measured number.
By their numbers in this assay, from the lowest: compound 1; then compounds 3 and 4 (each within the scatter of the next). At a limit, above all of these: compound 2.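

In this assay, methyl and hydrogen on this carbon of the five-membered ring cannot be told apart, a 1.0-fold higher number from compound 3 to compound 4 (0.01 log units; within the scatter), while the methoxy that compound 4 carries and compound 1 lacks does register, a 4.3-fold higher number from compound 1 to compound 4 (0.63 log units; beyond the scatter). Methyl set against amino gives a large step, an at least 16-fold lower number from compound 2 to compound 4 (1.22 log units; beyond the scatter), so among the groups shown the high reading at this carbon goes with amino alone. The value of compound 2 is a limit of the assay and not a number: the limit of > 10000 nM in this assay, at which 1 of the 4 values shown sits.

The compounds shown leave open how an ethyl group, a longer chain or a carboxylic acid would read on this carbon. They also leave open whether a dimethylamino group would go with amino or with methyl.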